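Lengthening a chain, then swapping the benzoyl cap

The source may report more compounds than this note shows. Statements on the series, on what has been measured and on what is new or still open speak of the compounds shown alone.

Measured compounds:
compound 1 `CCCCCCCCNC(=O)[C@@H](NC(=O)c1ccccc1)[C@@H](C)O`: 111000 nM
compound 2 `CCCCCCCCCCCCCCCCCCNC(=O)[C@@H](NC(=O)c1ccccc1)[C@@H](C)O`: 31800 nM

Going by the values given here, in a functional assay on MCF7 cells (Homo sapiens) for cytotoxicity, read by MTT assay, with a stated time of 48 h (a higher number here means a weaker inhibitor, a lower number a stronger inhibitor), compound 2 stands lowest of the two numbers, and the one step known, a 3.5-fold lower number from compound 1 to compound 2 (0.54 log units; beyond the scatter), is modest but beyond the scatter. Compound 3 `CCCCCCCCCCCCCCCCCCNC(=O)[C@@H](NC(=O)c1nccc2ccccc12)[C@@H](C)O` keeps the long chain and changes only the cap: isoquinolin-1-yl in place of phenyl on a carbonyl carbon. Among the compounds with values here, no measured step touches this cap, so the one known step gives no guide here. The change is expected to leave this assay roughly where it is, with the step of a 1.3-fold lower number from compound 2 to compound 3 (0.10 log units; within the scatter) estimated as small. Compound 3 is thus expected at 25000 nM, within 8000 nM to 80000 nM.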

Compound 3, half-maximal inhibitory concentration: 30800 nM
The estimate for compound 3 lay 1.2-fold (0.09 log units) below the measured number, within the range that was stated.
By their numbers in this assay, from the lowest: compounds 3 and 2 (each within the scatter of the next); then compound 1.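

Going from phenyl to isoquinolin-1-yl on a carbonyl carbon gives a 1.0-fold lower number from compound 2 to compound 3 (0.01 log units; within the scatter) in this assay, the first step at this position. Here, the cap can therefore carry the added ring with its nitrogen without a change beyond the scatter. No measured evidence bears on why this is so.

Going by these compounds, it remains open whether a cap bearing an amine or a carboxylic acid would shift the number. The same goes for whether isoquinolin-1-yl would behave alike on the shorter chain of compound 1.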